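Trimming Hydroxymethyl to Hydroxy at the Aromatic Carbon

The compounds below may be only part of what the source reports. "The series", "measured", "known", "first", "only" and "open" are said of these compounds alone.

Of the compounds shown here, two have been measured so far. Compound 1 `NC(=O)c1ccccc1-c1ccc(COC2CC[C@H](N3CCCCCC3)[C@H]2OC/C=C\CCC(=O)O)cc1` gives 15.9 nM in a functional assay on blood for antagonist activity at thromboxane A2 receptor (Homo sapiens) (on this read-out higher numbers stand for weaker binding and lower numbers for tighter binding), and compound 2 `O=C(O)CC/C=C\CO[C@H]1C(OCc2ccc(-c3ccccc3CO)cc2)CC[C@@H]1N1CCCCCC1` gives 3.16 nM in this assay. For the measured compounds named here, compound 2 therefore stands with the lower of the two numbers, and the only recorded step, a 5.0-fold lower number from compound 1 to compound 2 (0.70 log units; beyond the scatter), came from putting hydroxymethyl in place of carbamoyl on an aromatic carbon. Compound 3 `O=C(O)CC/C=C\CO[C@H]1C(OCc2ccc(-c3ccccc3O)cc2)CC[C@@H]1N1CCCCCC1` has not yet been measured; it differs from compound 2 by hydroxy in place of hydroxymethyl on an aromatic carbon. Going by the values given here, the earlier step bears on this one only loosely: it shows that the group on this aromatic carbon can move the number by a modest amount, but no measured pair swaps hydroxymethyl for hydroxy. The group merely grows shorter while keeping its donor and acceptor. A change close to the scatter is expected, in either direction. Compound 3 is therefore estimated at 4 nM, with a range from 1.5 nM to 12 nM, which would mean a 1.3-fold higher number from compound 2 to compound 3 (0.10 log units; within the scatter).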

Compound 3, dissociation constant: 15.9 nM
Compound 3: middle estimate off by 4.0-fold (0.60 log units), on the low side; the measured number lies above the stated range.
By their numbers in this assay, from the lowest: compound 2; then compounds 1 and 3 (each within the scatter of the next).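

In this assay, hydroxy in place of hydroxymethyl gives a 5.0-fold higher number from compound 2 to compound 3 (0.70 log units; beyond the scatter) even though the counts of hydrogen-bond donors and acceptors stay the same, so at this aromatic carbon those counts alone do not settle the number. Hydroxy in place of carbamoyl gives no change at the digits printed from compound 1 to compound 3 (within the scatter), which leaves hydroxymethyl as the only one of the three groups whose compound stands apart from the other two, with the lowest number. No measurement on hand says what lies behind this difference between hydroxymethyl and hydroxy.

Still open, on these data alone, is whether a longer chain such as hydroxyethyl would hold, lower or raise the number of compound 2. An amine or a carboxylic acid on this aromatic carbon also remains untested in the compounds shown here.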